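Benzylamino series: dichlorophenyl to dimethoxyphenyl step

A few compounds are considered here, and "the series" means these few. Any claim that something is new, unique, unknown or untested is made for them only; others in the source may bear on it.

Measured so far:
compound 1 `Nc1cc(N)c2nc(-c3ccccc3)c(Oc3ccc(Cl)c(Cl)c3)nc2c1` — < 100000 nM
compound 2 `Nc1cc(N)c2nc(-c3ccccc3)c(NCc3ccc(Cl)c(Cl)c3)nc2c1` — 1820 nM

Among the compounds with values here, in a functional assay on CCRF-CEM cells (Homo sapiens) for inhibition, read by sulforhodamine B assay, with a stated time of 48 h (on this read-out higher numbers stand for weaker inhibition of growth and lower numbers for stronger inhibition of growth), compound 2 gives 1820 nM, and this is the only number in the set. For compound 1 the read-out is a limit of the assay and not a number (the limit of < 100000 nM in this assay, at which 1 of the 2 values shown sits); nothing further can be said of it. Within the data shown here, compound 2 therefore stands alone as the single measured point, and no step between two measured compounds is available.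

Compound 3 `COc1ccc(CNc2nc3cc(N)cc(N)c3nc2-c2ccccc2)cc1OC` differs from compound 2 by 3,4-dimethoxyphenyl in place of 3,4-dichlorophenyl on a saturated chain carbon bound to a nitrogen on an aromatic ring, in words: 3,4-dimethoxyphenyl in place of 3,4-dichlorophenyl on a saturated chain carbon bound to a nitrogen on an aromatic ring. The rest of the shared core is unchanged.

Among the measured compounds shown here, with no measured pair of this kind, the step from compound 2 to compound 3 is expected to be a 2.2-fold higher number from compound 2 to compound 3 (0.34 log units; beyond the scatter), a small move toward weaker inhibition of growth that may not exceed the usual scatter. Compound 3 is estimated to give about 4000 nM in this assay, with a range from 1000 nM to 16000 nM.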

Compound 3, concentration for total growth inhibition: 70800 nM
For compound 3 the middle estimate is 18-fold (1.25 log units) below the measured one, outside the stated range (above it).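

In this assay, the 3,4-dichlorophenyl on a saturated chain carbon bound to a nitrogen on an aromatic ring now has a first measured comparison, and the change to 3,4-dimethoxyphenyl is not a neutral one: the step is a 39-fold higher number from compound 2 to compound 3 (1.59 log units; beyond the scatter). With the rest of the shared core unchanged, this position is shown to be sensitive to the group it carries, and of the two groups compared, 3,4-dichlorophenyl gives the stronger inhibition of growth, while the exchange adds 2 hydrogen-bond acceptors and moves from 8 to 10 heavy atoms. Within the data shown here, compound 1 remains a limit of the assay and adds no further step: the limit of < 100000 nM in this assay, at which 1 of the 3 values shown sits.

This single pair changes both ring substituents at once, so it cannot tell whether the step follows from one of them or from the two together. On these data alone, how an unsubstituted phenyl, a 4-chlorophenyl or a 3,4-dimethylphenyl on the same chain carbon would read remains open, as does whether the size of this step holds for any other group at this position.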